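Carbamate in Place of a Furanamide Linker on the Core

The source may hold more compounds than are shown below. What is called first, only, known or untested is meant among the compounds shown, and "the series" means these compounds.

Compound 2 `CC(C)=CCC/C(C)=C/CC1Cc2c(OCCCNC(=O)c3ccco3)cc(=O)n(CCCO)c2CC1(C)C` stands highest of the three compounds measured in a functional assay on PANC-1 cells (Homo sapiens) for inhibition, read by MTT assay, with a stated time of 24 h, tested at 10 uM (on this read-out higher numbers stand for more inhibition at the one concentration tested (going by the name of the read-out) and lower numbers for less inhibition), where compound 2 gives 69.5%. Compound 3 `CC(C)=CCC/C(C)=C/CC1Cc2c(OCCCOc3ccc([N+](=O)[O-])cc3)cc(=O)n(CCCO)c2CC1(C)C` gives 65.1%, and the step of a number 4.4 percentage points lower from compound 2 to compound 3 (within the scatter) lies within the scatter. Compound 1 `CC(C)=CCC1Cc2c(OCCCNC(=O)c3ccco3)cc(=O)n(CCCO)c2CC1(C)C`, which lacks the 3-methylbut-2-en-1-yl group, gives 2.1%; the step of a number 67.4 percentage points higher from compound 1 to compound 2 (beyond the scatter) is large.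

Compound 4 `CC(C)=CCC/C(C)=C/CC1Cc2c(OC(=O)Nc3ccc(Cl)cc3)cc(=O)n(CCCO)c2CC1(C)C` differs from compound 2 by (4-chlorophenyl)carbamoyl in place of 3-(((furan-2-yl)carbonyl)amino)propyl on an oxygen on an aromatic ring. Among the measured compounds shown here, of the measured steps, the one from compound 2 to compound 3 bears most closely on this change, since it also exchanges the group three bonds along the chain from the oxygen on the aromatic ring, and it stayed within the scatter. The step from compound 1 to compound 2, though large, concerns another part of the core, and both groups involved are retained in compound 4. For the measured compounds named here, no measured step removes the three-carbon chain itself, so that part of the change is unassessed and widens the uncertainty. Compound 4 is therefore expected to stay fairly close to compound 2. The expected step is a number 14.5 percentage points lower from compound 2 to compound 4 (beyond the scatter), a modest lowering that may not clear the scatter. The estimate for compound 4 in this assay is 55%, with a range from 25% to 80%.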

Compound 4, a percentage reported as inhibition, at one concentration (the size of the read-out at that concentration, not a potency): 47.2%
Estimate against measurement, compound 4: 7.8 percentage points above, within the range that was stated.
By their numbers in this assay, from the lowest: compound 1; then compound 4; then compounds 3 and 2 (each within the scatter of the next).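

In this assay, putting (4-chlorophenyl)carbamoyl in place of 3-(((furan-2-yl)carbonyl)amino)propyl on the oxygen on an aromatic ring gives a number 22.3 percentage points lower from compound 2 to compound 4 (beyond the scatter), whereas the exchange further out on the chain, a number 4.4 percentage points lower from compound 2 to compound 3 (within the scatter), did not clear the scatter. This shows that the result can depend on what is attached directly to this oxygen, although the step is only modest and compound 4 still gives 47.2% without the propyl chain or the furan ring that compound 2 carries. No available information accounts for this lowering.

The single change replaces the chain, the furan ring and the amide together with a carbamoyl group and a chlorophenyl ring, so the shown compounds cannot assign the step to any one of these parts. Going by these compounds, it remains open whether a phenylcarbamoyl group without the chlorine, a furan-2-yl carbamoyl group, or a propyl chain ending in an amine or a carboxylic acid would give a number nearer that of compound 2 or that of compound 4.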